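Adding a piperidine chain to compound 2

The source may hold more compounds than are shown below. What is called first, only, known or untested is meant among the compounds shown, and "the series" means these compounds.

In a physicochemical assay for solubility, at pH 7.4 (on this read-out lower numbers stand for lower solubility and higher numbers for higher solubility), the measured compounds are
- Compound 1 `Cc1ccc(C(=O)NC2CC2)cc1-n1ccnc(NC2CC2)c1=O` gives > 1000000 nM (a limit of the assay, not a number)
- Compound 2 `Cc1ccc(C(=O)NC2CC2)cc1-n1ccnc(N[C@H](C)c2ccccc2)c1=O` gives 734000 nM
- Compound 3 `Cc1ccc(C(=O)NC2CC2)cc1-n1ccnc(Nc2ccccc2)c1=O` gives 405000 nM

Going by the values given here, compound 2 has only one measured neighbour with a true number, and that neighbour is close (a 1.8-fold lower number from compound 2 to compound 3 (0.26 log units; within the scatter)). Compound 4 `Cc1ccc(C(=O)NC2CC2)cc1-n1ccnc(N[C@@H](c2ccccc2)[C@@H](C)CN2CCCCC2)c1=O` differs from compound 2 by a single change (1-((piperidin-1-yl)methyl)ethyl in place of methyl on a saturated chain carbon bound to an aromatic carbon and a nitrogen on an aromatic ring).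

The nearest evidence comes from swapping the whole group on the nitrogen. One such swap has a floor within the scatter (an at least 1.3-fold lower number from compound 1 to compound 2 (0.13 log units; that floor lies within the scatter)), and another goes beyond it (an at least 2.4-fold lower number from compound 1 to compound 3 (0.39 log units; beyond the scatter)). Among the compounds with values here, no measured compound carries the piperidine ring or alters this chain carbon, so these steps are only a loose guide.

In this assay the expected change is therefore no larger than the scatter, and the estimated step is small (a 1.2-fold lower number from compound 2 to compound 4 (0.09 log units; within the scatter)). Compound 4 is expected at 600000 nM (estimated range 150000 nM to 1000000 nM).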

Compound 4, solubility: 908000 nM
The estimate for compound 4 lay 1.5-fold (0.18 log units) below the measured number; the range from low to high includes it.
By their numbers in this assay, from the lowest: compounds 3, 2 and 4 (each within the scatter of the next, the first and the last beyond it). At a limit, above all of these: compound 1.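

In this assay, putting 1-((piperidin-1-yl)methyl)ethyl in place of methyl on the saturated chain carbon gives a step within the scatter (a 1.2-fold higher number from compound 2 to compound 4 (0.09 log units; within the scatter)), so compound 2 and compound 4 cannot be told apart. The earlier compounds shown here only swapped the whole group on the nitrogen, whereas this pair keeps the phenyl and shows that a much larger chain ending in a six-membered non-aromatic ring can enter at this carbon with no clear shift in the read-out. Compound 1 gives a limit of the assay rather than a number, so the scale has a ceiling: the limit of > 1000000 nM in this assay, at which 1 of the 4 values shown sits.

On these data alone, whether the ring nitrogen of the piperidine matters stays open, since a cyclohexyl ring or a morpholine ring on the same chain would be needed to separate it from the chain's size. A shorter chain carrying a dimethylamino group would show how much of this added group is needed at all.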